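This account rests on a few compounds, and the source may have more. Where it says the series, first, only, none or still open, it means among the compounds named here.

Working notes on the series. In a functional assay on HL-60 cells (Homo sapiens) for antiproliferative activity, read by MTT assay, with a stated time of 72 h (on this read-out higher numbers stand for weaker inhibition and lower numbers for stronger inhibition), compound 1 (`CC(C)(C)c1ccc(OCCCON2C(N)=NC(N)=NC23CCSCC3)cc1`) gives 280 nM and compound 2 (`NC1=NC2(CCSCC2)N(OCCCOc2cccc(Br)c2)C(N)=N1`) gives 200 nM. Within the data shown here, compound 2 therefore stands within the scatter of compound 1, the only other number available, and the two cannot be ranked. Compound 3 (`COc1ccc(OCCCON2C(N)=NC(N)=NC23CCSCC3)cc1`) has no number yet. Its change from compound 2 is 4-methoxyphenyl in place of 3-bromophenyl on an oxygen on a saturated carbon. Among the measured compounds shown here, no measured pair isolates a single change, so this swap has no direct precedent. The data offer only a narrow spread, with compound 1 at 280 nM lying within the scatter of compound 2 at 200 nM. On that basis, a small move towards a higher number is expected in this assay, with nothing expected beyond the scatter. The estimated change is a 1.8-fold higher number from compound 2 to compound 3 (0.24 log units; within the scatter). For the measured compounds named here, the uncertainty remains wide, since only two values support the estimate. For compound 3, the expected value is 350 nM, with an estimated range of 120 nM to 1000 nM.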

Compound 3, half-maximal inhibitory concentration: 500 nM
The estimate for compound 3 lay 1.4-fold (0.15 log units) below the measured number; low and high end bracket the measured number.
By their numbers in this assay, from the lowest: compounds 2, 1 and 3 (each within the scatter of the next, the first and the last beyond it).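

In this assay, 4-methoxyphenyl in place of 3-bromophenyl on an oxygen on a saturated carbon gives a 2.5-fold higher number from compound 2 to compound 3 (0.40 log units; beyond the scatter). Among these compounds, this is the first step to lie beyond the scatter, and it shows that the aryl group at this place can shift the read-out, though only modestly, towards weaker inhibition. Methoxy in place of tert-butyl on an aromatic carbon gives a 1.8-fold higher number from compound 1 to compound 3 (0.25 log units; within the scatter), which stays within the scatter, so compound 1 and compound 3 cannot be ranked, and this second change shows no clear effect on its own. Nothing at hand bears on the reason for either step.

The swap from compound 2 to compound 3 changes both the substituent and the numbered place it holds on the phenyl ring, so the two contributions remain tangled; 3-methoxyphenyl or 4-bromophenyl would be needed to separate them. On these data alone, how an unsubstituted phenyl, or a ring carrying an amine or a carboxylic acid, would read in this assay also remains open, as does the effect of a longer chain between the two oxygens.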